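The source may report more compounds than this note shows. Statements on the series, on what has been measured and on what is new or still open speak of the compounds shown alone.

Compound 1 `COc1ccc(C2=C(c3cc(OC)c(OC)c(OC)c3)C(=O)CC2O[SiH2]C(C)(C)C)cc1OC`, compound 2 `COCOc1cc(C2=C(c3cc(OC)c(OC)c(OC)c3)C(=O)CC2O[SiH2]C(C)(C)C)ccc1OC` and compound 3 `COc1ccc(C2=C(c3cc(OC)c(OC)c(OC)c3)C(=O)CC2C)cc1C(=O)O` share one core, a five-membered non-aromatic ring carrying two aryl groups. In an ADME assay on HT-29 cells (Homo sapiens) for cytotoxicity, read by MTT assay, with a stated time of 72 h (on this read-out higher numbers stand for weaker inhibition and lower numbers for stronger inhibition), compound 1 gives only a limit, > 100 ug/mL. Compound 3 also gives only a limit in this assay, > 100 ug/mL. Compound 2 stands apart, giving a true number in this assay, 43 ug/mL, while the other two values sit at the limit of > 100 ug/mL in this assay, at which 2 of the 3 values shown sit. Going by the values given here, the one measured step is an at least 2.3-fold lower number from compound 1 to compound 2 (0.36 log units; beyond the scatter), and it concerns the same aryl ring that changes next.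

Compound 4 `COc1cc(C2=C(c3ccccc3)C(O[SiH2]C(C)(C)C)CC2=O)cc(OC)c1OC` differs from compound 2 in that ring: phenyl in place of 4-methoxy-3-(methoxymethoxy)phenyl on a double-bonded ring carbon. The measured step shows that adding a methoxy to a chain carbon on this ring made inhibition stronger; compound 4 instead strips the ring of every oxygen. A step back toward weaker inhibition in this assay is therefore expected, of size a 2.3-fold higher number from compound 2 to compound 4 (0.37 log units; beyond the scatter). Compound 4 is thus estimated at 100 ug/mL, within a range from 40 ug/mL to 250 ug/mL.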

Compound 4, half-maximal inhibitory concentration: > 100 ug/mL
Compound 4: only a limit was reported; the forecaster's own chance of this, stated with the estimate: 60%; the middle value lies on the limit itself.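

In this assay compound 4 gives > 100 ug/mL, which is a limit and not a number. As far as these compounds go, putting phenyl in place of 4-methoxy-3-(methoxymethoxy)phenyl on this double-bonded ring carbon gives an at least 2.3-fold higher number from compound 2 to compound 4 (0.36 log units; beyond the scatter), so plain phenyl does not keep the inhibition seen with compound 2, and the true size of the loss stays unknown. The step between compound 1 and compound 4 cannot be read, and compound 2 remains the only compound with a true number: the limit of > 100 ug/mL in this assay, at which 3 of the 4 values shown sit.

Still open is which part of 4-methoxy-3-(methoxymethoxy)phenyl accounts for the difference, the methoxy or the methoxymethoxy. Also open, from the compounds shown here alone, is whether a hydroxyl or an amine on this aryl ring would give a true number in this assay.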